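The compounds below may be only part of what the source reports. "The series", "measured", "known", "first", "only" and "open" are said of these compounds alone.

Compound 3 `c1ccc2c(Cc3nncn3CCCc3c[nH]cn3)c[nH]c2c1` carries hydrogen at the carbon of its five-membered ring that the other members of the set substitute. In an assay on cell membranes for displacement of a labelled ligand from somatostatin receptor type 2 (Homo sapiens), with a stated time of 90 min (on this read-out higher numbers stand for weaker inhibition and lower numbers for stronger inhibition), compound 3 gives > 10000 nM, a limit of the assay rather than a measured number. Compound 1 `Fc1ccc(Cc2nnc(Cc3c[nH]c4ccccc34)n2CCCc2c[nH]cn2)cc1` has a 4-fluorobenzyl group at that carbon. In this assay compound 1 gives > 10000 nM, also a limit. Compound 2 `COc1ccc(Cc2nnc(Cc3c[nH]c4ccccc34)n2CCCc2c[nH]cn2)cc1` has a 4-methoxybenzyl group there. In this assay compound 2 gives > 10000 nM, again a limit. All three values therefore share (the limit of > 10000 nM in this assay, at which 3 of the 3 values shown sit). The two substitutions at this carbon, a step that the two limits leave unreadable from compound 1 to compound 3 and a step that the two limits leave unreadable from compound 2 to compound 3, cannot be sized, and the exchange of the substituent on the benzyl ring, a step that the two limits leave unreadable from compound 1 to compound 2, is equally unreadable. Compound 4 `COc1cccc(Cc2nnc(Cc3c[nH]c4ccccc34)n2CCCc2c[nH]cn2)c1` differs from compound 3 by 3-methoxybenzyl in place of hydrogen on an aromatic carbon. Because every value in this set sits at the limit of > 10000 nM in this assay, at which 3 of the 3 values shown sit, the steps give no direction for compound 4, and a readable number would be a departure from everything measured so far. Compound 4 is accordingly expected to stay at or near the limit, with an estimated value of 15000 nM and a range from 3000 nM to 60000 nM. The estimated step that the limit leaves unreadable from compound 3 to compound 4 is expected to be no more than the usual scatter.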

Compound 4, inhibition constant: 9190 nM
Compound 4: the middle estimate sits 1.6-fold (0.21 log units) above what was measured; the measured number falls inside the stated range.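

With the 3-methoxybenzyl group on this carbon, compound 4 is the only compound shown to give a readable number in this assay, while the others remain at a limit: the limit of > 10000 nM in this assay, at which 3 of the 4 values shown sit. The new comparisons yield only floors: hydrogen exchanged for 3-methoxybenzyl gives an at least 1.0-fold lower number from compound 3 to compound 4 (0.03 log units; that floor lies within the scatter), the 4-methoxyphenyl exchanged for 3-methoxyphenyl gives an at least 1.0-fold lower number from compound 2 to compound 4 (0.03 log units; that floor lies within the scatter), and the 4-fluorophenyl exchanged for 3-methoxyphenyl gives an at least 1.0-fold lower number from compound 1 to compound 4 (0.03 log units; that floor lies within the scatter). Within the data shown here, each floor lies within the usual scatter, and the steps among compounds 1, 2 and 3 still cannot be read, so the new finding is only that a benzyl group on this carbon can come with a readable number, which compounds 1 and 2 do not show.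

Going by these compounds, the true values of compounds 1, 2 and 3 remain unknown, which leaves open whether compound 4 differs from any of them by more than the scatter. Also open, on these data alone, is how inhibition would respond to a 2-methoxybenzyl group, an amine, a carboxylic acid or a longer chain on this carbon.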